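Swapping a cyanophenyl for a pyridinyl on a shared core

The compounds below may be only part of what the source reports. "The series", "measured", "known", "first", "only" and "open" are said of these compounds alone.

Of the compounds shown here, two have been measured so far. In a functional assay on HCT-116 cells (Homo sapiens) for inhibition, read by MTT assay, with a stated time of 24 h, tested at 5 uM (on this read-out lower numbers stand for less inhibition of growth and higher numbers for more inhibition of growth at the one concentration tested), compound 1 `N#Cc1ccc(-c2cnc3[nH]cc(-c4nnc(-c5ccc(F)cc5)o4)c(=O)c3c2)cc1` gives 12.6%, and compound 2 `CS(=O)(=O)c1ccc(-c2cnc3[nH]cc(-c4nnc(-c5ccncc5)o4)c(=O)c3c2)cc1` gives 5.61%, a gap that lies within the scatter of repeat measurements, so the two stand level at modest growth inhibition. Compound 3 `O=c1c(-c2nnc(-c3ccc(F)cc3)o2)c[nH]c2ncc(-c3cccnc3)cc12` has not yet been measured. It differs from compound 1 in one place (pyridin-3-yl in place of 4-cyanophenyl on an aromatic carbon). Going by the values given here, no measured step of this kind is available, so the change is expected to move this assay little, if at all, beyond the scatter, and the step of a number 1.6 percentage points lower from compound 1 to compound 3 (within the scatter) is estimated as small. Compound 3 is expected to give about 11%, most likely between 0% and 25%.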

Compound 3, percent growth inhibition at one concentration: 11.1%
Compound 3: the middle estimate sits 0.1 percentage points below what was measured; low and high end bracket the measured number.
By their numbers in this assay, from the lowest: compounds 2, 3 and 1 (each within the scatter of the next).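

In this assay the swap of 4-cyanophenyl for pyridin-3-yl amounts to a number 1.5 percentage points lower from compound 1 to compound 3 (within the scatter) and so leaves growth inhibition level. At this position, then, the nitrile and the all-carbon aromatic ring of compound 1 are not needed to keep the modest inhibition seen at the one concentration tested. Nothing measured here explains this result.

Still open, from the compounds shown here alone, is whether a non-aromatic group at this position, such as an amine or a carboxylic acid, would move the number beyond the scatter.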